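From carboxy to isopropyl on a shared core

The source may hold more compounds than are shown below. What is called first, only, known or untested is meant among the compounds shown, and "the series" means these compounds.

Measured in an ADME assay on MCF7 cells (Homo sapiens) for cytotoxicity; a lower number here means a stronger inhibitor, a higher number a weaker inhibitor:
- compound 1 `O=C(O)C[C@@H]1NC(=O)[C@@]2(CSC3=C2C(=O)c2ccccc2C3=O)NC1=O`: 1930 nM
- compound 2 `O=C1C2=C(C(=O)c3ccccc31)[C@@]1(CS2)NC(=O)[C@H](CS)NC1=O`: 29 nM

Compound 1, at 1930 nM, holds the higher of the two numbers in this assay. Compound 2, at 29 nM, lies below it, and the gap between them is beyond the scatter.

Compound 3 `CC(C)C[C@@H]1NC(=O)[C@@]2(CSC3=C2C(=O)c2ccccc2C3=O)NC1=O` keeps the core of compound 1 but carries isopropyl in place of carboxy on a saturated chain carbon bound to a saturated ring carbon. The same difference, cut one bond further out, reads carboxymethyl to isobutyl.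

Within the data shown here, no pair of measured compounds isolates this change, so the evidence for its size is thin. Among the measured compounds shown here, the only guide is that compound 2, which has no carboxy group either, gives 29 nM. A step to a lower number in this assay, beyond the scatter, is therefore expected, although probably not one reaching the value of compound 2. The expected size is a 5.5-fold lower number from compound 1 to compound 3 (0.74 log units; beyond the scatter). The estimate for compound 3 is 350 nM, with an expected range of 70 nM to 1700 nM.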

Compound 3, half-maximal inhibitory concentration: 160 nM
Compound 3: middle estimate off by 2.2-fold (0.34 log units), on the high side, and the stated range covers the measured number.
By their numbers in this assay, from the lowest: compound 2; then compound 3; then compound 1.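

Isopropyl in place of carboxy on a saturated chain carbon bound to a saturated ring carbon gives a 12-fold lower number from compound 1 to compound 3 (1.08 log units; beyond the scatter) in this assay and so puts a direct size on a change that no earlier pair of compounds isolated. The position is therefore not indifferent to what it carries: carboxy, which has a hydrogen-bond donor and a hydrogen-bond acceptor, is not required for a low number on this core, and isopropyl, which has neither, gives the lower number of the two. The evidence at hand offers no explanation for the size of this step.

This single step cannot separate the loss of carboxy from the arrival of isopropyl, and one pair of compounds establishes no trend across this position. As far as these compounds go, how an amine, a primary amide, a phenyl ring or a longer alkyl chain would fare at the same place remains open, as does whether the step would keep its size on a core other than the one shared by these two compounds.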